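A second trifluoromethyl group on compound 2

This account rests on a few compounds, and the source may have more. Where it says the series, first, only, none or still open, it means among the compounds named here.

Compound 1 `Nc1nc2cc(Cl)c(Cl)cc2n1Cc1cc(C(F)(F)F)cc(C(F)(F)F)c1`: 17000 nM
Compound 2 `FC(F)(F)c1cccc(Cn2c(Cl)nc3cc(Cl)c(Cl)cc32)c1`: > 100000 nM
Compound 3 `FC(F)(F)c1cc(Cn2c(Cl)nc3cc(Cl)c(Cl)cc32)cc(C(F)(F)F)c1`: not yet measured

These compounds were examined in a functional assay on CEM-SS cells (Homo sapiens) for cytotoxicity; a higher number here means a weaker inhibitor, a lower number a stronger inhibitor. Going by the values given here, compound 1 gives 17000 nM, the only true number in this small set. Compound 2 stands at > 100000 nM, and this is a limit of the assay, not a number. Its position in this assay is therefore known only as a limit.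

Compound 3 departs from compound 2 at a single place: trifluoromethyl in place of hydrogen on an aromatic carbon. Trifluoromethyl replaces hydrogen on an aromatic carbon of a six-membered aromatic ring of carbon only, meta to a large group and meta to a trifluoromethyl group. Among the compounds with values here, no measured pair isolates this change, so its size cannot be read directly from the data. The expectation is a moderate move toward a stronger reading, guided by compound 1 at 17000 nM. Even so, a result for compound 3 at the limit of the assay would be no surprise.

The expected change is an at least 2.2-fold lower number from compound 2 to compound 3 (0.34 log units; beyond the scatter). For compound 3 the estimated value is 45000 nM, with an expected range from 15000 nM to 100000 nM.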

Compound 3, half-maximal inhibitory concentration: > 100000 nM
Compound 3: only a limit was reported; the forecaster's own chance of this, stated with the estimate: 40%; middle value at least 2.2-fold (0.34 log units) from the limit.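

In this assay, going by these compounds alone, the added trifluoromethyl group produced no readable change, because compound 2 and compound 3 both stand at the limit, so their step cannot be read: the limit of > 100000 nM in this assay, at which 2 of the 3 values shown sit. Compound 3 does provide a comparison that the earlier compounds lacked, since it differs from compound 1 in one place, with chloro in place of amino on an aromatic carbon, and this gives an at least 5.8-fold higher number from compound 1 to compound 3 (0.76 log units; beyond the scatter). With both trifluoromethyl groups present in compound 1 and compound 3, the two trifluoromethyl groups alone are therefore not enough to bring the reading inside the range of the assay, and among these compounds a true number appears only with the amino group.

The compounds shown leave open whether the second trifluoromethyl group makes any difference when the amino group is present, as the only readable step concerns the chloro and amino exchange. They also leave open whether a hydroxyl group or a methylamine on that same aromatic carbon would give a true number like that of compound 1, or a limit like that of compound 3.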